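Swapping methoxyphenyl for difluorophenyl in a cytotoxicity series

A few compounds are considered here, and "the series" means these few. Any claim that something is new, unique, unknown or untested is made for them only; others in the source may bear on it.

Three measured compounds and one awaiting measurement share a single core. Compound 1 `CCOC(=O)c1cc(-c2cccc(OCc3cccc(OC(F)(F)F)c3)c2)on1` is the only one with a numerical result: in an ADME assay on Vero cells (Chlorocebus sabaeus) for cytotoxicity, with a stated time of 72 h (a lower number here means a stronger inhibitor, a higher number a weaker inhibitor), compound 1 gives 101000 nM. Compound 2 `CCOC(=O)c1cc(-c2cccc(OCc3cccc(OC)c3)c2)on1` reaches a limit of the assay rather than a number: in this assay compound 2 gives > 128000 nM. Compound 3 `CCOC(=O)c1ccc(COc2cccc(-c3cc(C(=O)OCC)no3)c2)cc1` also sits at a limit: in this assay compound 3 gives > 128000 nM. Compound 2 therefore stands at the weak end of what this assay can report, namely (the limit of > 128000 nM in this assay, at which 2 of the 3 values shown sit). Compound 4 `CCOC(=O)c1cc(-c2cccc(OCc3ccc(F)cc3F)c2)on1` differs from compound 2 in one place: 2,4-difluorophenyl in place of 3-methoxyphenyl on a saturated chain carbon bound to an oxygen on an aromatic ring. Among the compounds with values here, no measured step exchanges one aromatic ring for another; the only measured step, an at least 1.2-fold higher number from compound 1 to compound 2 (0.10 log units; that floor lies within the scatter), concerns a group on an oxygen and stays within the scatter, so it offers little guidance. Compound 4 is accordingly expected to show an at least 1.1-fold lower number from compound 2 to compound 4 (0.04 log units; that floor lies within the scatter). In this assay the value estimated for compound 4 is 115000 nM, between 55000 nM and 260000 nM.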

Compound 4, half-maximal inhibitory concentration: > 128000 nM
Compound 4 gave a limit, no number (the forecaster's own chance of this, stated with the estimate: 55%); at least 1.1-fold (0.04 log units) between middle value and limit.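

In this assay compound 2 and compound 4 both reach a limit rather than a number, so the step between them cannot be read: the limit of > 128000 nM in this assay, at which 3 of the 4 values shown sit.

The compounds shown leave open how far past that limit each lies, and whether exchanging 3-methoxyphenyl for 2,4-difluorophenyl changes the result at all.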